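The source may report more compounds than this note shows. Statements on the series, on what has been measured and on what is new or still open speak of the compounds shown alone.

Measured so far, lipophilicity as a physicochemical assay for lipophilicity, using the shake flask method, measured as octanol-water partition, at pH 7.4; on this read-out higher numbers stand for higher lipophilicity and lower numbers for lower lipophilicity:
compound 1 `COc1cc(/C=C/C(=O)Nc2ccccc2)ccc1OCCCN1CCCCC1` gives 1.58;
compound 2 `COc1cc(/C=C/C(=O)Nc2ccccc2)ccc1OCCCCCN(C)C` gives 1.61.

Compound 2 stands highest of the two numbers, yet only by the step of a number 0.03 log units higher from compound 1 to compound 2 (within the scatter), so the two sit together. Compound 3 `COc1cc(/C=C/C(=O)Nc2ccccc2)ccc1OCCCCCN1CCCCC1` differs from compound 2 by piperidin-1-yl in place of dimethylamino on a saturated chain carbon, five bonds along the chain from an oxygen on an aromatic ring. Among the compounds with values here, the single measured step, from compound 1 to compound 2, changes the amine and the chain length at once and so does not isolate the amine swap alone. On the added ring carbons alone, compound 3 is expected to rise in this assay by a number 0.89 log units higher from compound 2 to compound 3 (beyond the scatter), to an estimated 2.5, within 1.9 to 3.1.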

Compound 3, partition coefficient: 1.65
For compound 3 the middle estimate is 0.85 log units above the measured one; measured number outside the range, below it.
By their numbers in this assay, from the lowest: compounds 1, 2 and 3 (each within the scatter of the next).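

In this assay, piperidin-1-yl in place of dimethylamino on a saturated chain carbon, five bonds along the chain from an oxygen on an aromatic ring, gives a number 0.04 log units higher from compound 2 to compound 3 (within the scatter), so the swap of amine alone leaves the two compounds together. With piperidin-1-yl held fixed, the chain step 2-(piperidin-1-yl)ethyl in place of piperidin-1-yl gives a number 0.07 log units higher from compound 1 to compound 3 (within the scatter), which separates chain length from the amine and again leaves the numbers together. Nothing available accounts for this flatness. Still open, as far as these compounds go, is whether a morpholin-4-yl group or a carboxylic acid in place of the amine would move this read-out, and whether a longer chain would do so.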